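Aminopyrimidinone series: pyrazolyl substituent replacing the substituted pyridinyl

A few compounds are considered here, and "the series" means these few. Any claim that something is new, unique, unknown or untested is made for them only; others in the source may bear on it.

Working notes on the series. Compound 1 `COc1ccc(-c2cc3c(C)nc(N)nc3n([C@H]3CC[C@@H](OCO)CC3)c2=O)cn1` is the reference point: in an assay on BT-20 cells for inhibition of RAC-alpha serine/threonine-protein kinase (Homo sapiens) (on this read-out higher numbers stand for weaker inhibition and lower numbers for stronger inhibition), compound 1 gives 21.6 nM. Among the measured compounds shown here, compound 2 `COc1ncc(-c2cc3c(C)nc(N)nc3n([C@H]3CC[C@@H](OCO)CC3)c2=O)cc1F` carries the shared core with a different aryl group; in this assay compound 2 gives "not determined" (no result reported), so there is no single number for compound 2 on this read-out, and no step from compound 2 to any measured compound can be stated.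

Compound 3 `Cc1nc(N)nc2c1cc(-c1cn[nH]c1)c(=O)n2[C@H]1CC[C@@H](OCO)CC1` is the next member to be measured. It differs from compound 2 in one place: 1H-pyrazol-4-yl in place of 5-fluoro-6-methoxypyridin-3-yl on an aromatic carbon. For the measured compounds named here, since no measured step involving compound 2 exists, the size of the change in this assay cannot be read off from the series; the reading for compound 1 is the only anchor. A step of modest size toward weaker inhibition, or none beyond the scatter, is expected.

In this assay compound 3 is estimated at 50 nM, with a range from 8 nM to 300 nM.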

Compound 3, half-maximal inhibitory concentration: 11.2 nM
Estimate against measurement, compound 3: 4.5-fold (0.65 log units) above, and the stated range covers the measured number.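

In this assay, 1H-pyrazol-4-yl in place of 6-methoxypyridin-3-yl on this aromatic carbon gives a 1.9-fold lower number from compound 1 to compound 3 (0.29 log units; within the scatter), so this position accepts a five-membered aromatic ring with no step beyond the scatter. Among the compounds shown here, this is the first step that can be read at this position, as compound 1 alone offered a single reading and compound 2 offered none; the steps involving compound 2 cannot be read. No measurement shown for these groups bears on the result, and the step stands without an explanation.

From the compounds shown here alone, whether 1-methyl-1H-pyrazol-4-yl, a plain phenyl or a carboxylic acid on this aromatic carbon would stay within the scatter of compound 3 remains open. Also open, going by these compounds, is what the fluorine of 5-fluoro-6-methoxypyridin-3-yl contributes on this read-out, since the shared core with the 5-fluoro-6-methoxypyridin-3-yl group gives no number to set against compound 1 or compound 3.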